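A few compounds are considered here, and "the series" means these few. Any claim that something is new, unique, unknown or untested is made for them only; others in the source may bear on it.

Working notes on the series. Three compounds have numbers in an assay on isolated protein for inhibition of thyroid hormone receptor beta (Homo sapiens), read by fluorescence, with a stated time of 30 min; a lower number here means a stronger inhibitor, a higher number a weaker inhibitor. Compound 1 `O=C(NCc1cccc(Cl)c1)c1ccc2cn(CCN3CCOC3=O)nc2c1` gives 220 nM. Compound 2 `O=C(NCc1cccc(Cl)c1)c1cc(Cl)c2cn(CCn3cccn3)nc2c1` gives 225 nM. Compound 3 `COc1cc(C(=O)N2CCC(O)C(C)C2)cc2nc(NCc3cncc(Cl)c3)oc12` gives 7200 nM, the highest of the three numbers, and its gaps to compound 1 and to compound 2 both lie beyond the scatter. Among the measured compounds shown here, compound 3 is not a one-place relative of compound 1 or compound 2, so no step between measured compounds is available. Compound 4 `COc1cc(C(=O)N2CCC(O)C(C)C2)cc2nc(NCc3cc(Cl)ccc3O)oc12` differs from compound 3 by 5-chloro-2-hydroxyphenyl in place of 5-chloropyridin-3-yl on a saturated chain carbon bound to a nitrogen on an aromatic ring. For the measured compounds named here, no measured pair shows what this change does in this assay, so the expected step of a 1.4-fold lower number from compound 3 to compound 4 (0.16 log units; within the scatter) is taken as small and may stay within the scatter. Compound 4 is estimated at 5000 nM, with a range from 1500 nM to 16000 nM.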

Compound 4, half-maximal inhibitory concentration: 170 nM
Compound 4: middle estimate off by 29-fold (1.47 log units), on the high side, and the stated range ends above it.
By their numbers in this assay, from the lowest: compounds 4, 1 and 2 (each within the scatter of the next); then compound 3.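

In this assay, among the compounds shown here, the place on a saturated chain carbon bound to a nitrogen on an aromatic ring proves highly sensitive: 5-chloro-2-hydroxyphenyl in place of 5-chloropyridin-3-yl gives a 42-fold lower number from compound 3 to compound 4 (1.63 log units; beyond the scatter) as the first one-place step. Nothing at hand accounts for the size of this step. The hydroxy group and the exchange of ring nitrogen for carbon arrive together here, and the compounds shown do not separate them. As far as these compounds go, whether a chlorophenyl without the hydroxy group, or one carrying methoxy or an amine instead, keeps the low number stays open.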